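The source may hold more compounds than are shown below. What is called first, only, known or untested is meant among the compounds shown, and "the series" means these compounds.

Of the compounds shown here, three sharing one core have been measured in a functional assay on PC-3 cells (Homo sapiens) for inhibition; on this read-out higher numbers stand for weaker inhibition and lower numbers for stronger inhibition. Compound 1 `COc1cc2nc(N3CCN(S(=O)(=O)c4ccc(I)cc4)CC3)nc(N)c2cc1OC` gives 15000 nM, the lowest of the three numbers. Compound 2 `COc1cc2nc(N3CCN(S(=O)(=O)c4ccc(Cl)s4)CC3)nc(N)c2cc1OC` gives 25000 nM, and compound 3 `COc1cc2nc(N3CCN(S(=O)(=O)c4ccc(N)cc4N)CC3)nc(N)c2cc1OC` gives 67000 nM. The step of a 1.7-fold higher number from compound 1 to compound 2 (0.22 log units; within the scatter) stays within the scatter, while the step of a 4.5-fold higher number from compound 1 to compound 3 (0.65 log units; beyond the scatter) is a modest weakening. Compound 4 `COc1cc2nc(N3CCN(S(=O)(=O)c4ccc(-c5ccc(S(C)(=O)=O)cc5)cc4)CC3)nc(N)c2cc1OC` differs from compound 1 in one place: 4-(methylsulfonyl)phenyl in place of iodo on an aromatic carbon. Both measured steps alter the aryl group on the sulfonyl sulfur, yet neither tried an extension of this kind, so the guidance is thin. For compound 4 the expected step is no change at the digits printed from compound 1 to compound 4 (within the scatter), which amounts to no clear shift beyond the scatter. The estimate for compound 4 in this assay is 15000 nM, within a range from 4000 nM to 60000 nM.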

Compound 4, half-maximal inhibitory concentration: 7200 nM
Compound 4: middle estimate off by 2.1-fold (0.32 log units), on the high side; measured number inside the range.
By their numbers in this assay, from the lowest: compound 4; then compounds 1 and 2 (each within the scatter of the next); then compound 3.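

In this assay replacing iodo with the much larger 4-(methylsulfonyl)phenyl gives a 2.1-fold lower number from compound 1 to compound 4 (0.32 log units; beyond the scatter) and so shows that this position tolerates an added aromatic ring with no loss of inhibition. The earlier steps shown here swapped the whole aryl group on the sulfonyl sulfur and never gave a number lower than that of compound 1, whereas this extension does, though only modestly. Nothing measured here explains the gain. As far as these compounds go, whether a plain phenyl would do the same, or an amine or carboxylic acid on the added ring, remains open.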